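The compounds below may be only part of what the source reports. "The series", "measured", "known", "first", "only" and "open" are said of these compounds alone.

Working notes on the series. Compound 1 `O=C(O)C1(Sc2ccnc3cccnc23)CCC1` gives in an assay on HEK293 cells for inhibition of solute carrier family 22 member 12 (Homo sapiens), read by scintillation counting, with a stated time of 12 min (on this read-out lower numbers stand for stronger inhibition and higher numbers for weaker inhibition), only a limit, > 10000 nM, not a number. Among the measured compounds shown here, compound 2 `N#CCOc1ccc2nccc(SC3(C(=O)O)CCC3)c2c1` gives 680 nM in this assay, the single numerical value in the set so far. The other entry, that of compound 1, is a limit (the limit of > 10000 nM in this assay, at which 1 of the 2 values shown sits). Compound 3 `O=C(O)C1(Sc2ccnc3ccc(-c4ccccc4F)cc23)CCC1` differs from compound 2 by 2-fluorophenyl in place of cyanomethoxy on an aromatic carbon. For the measured compounds named here, no step between two measured compounds is available to calibrate this change. The expected step of a 2.3-fold lower number from compound 2 to compound 3 (0.36 log units; beyond the scatter) is a modest gain toward stronger inhibition, only just beyond the scatter. Compound 3 is expected to give 300 nM in this assay, within 60 nM to 2000 nM.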

Compound 3, half-maximal inhibitory concentration: 333 nM
The estimate for compound 3 lay 1.1-fold (0.05 log units) below the measured number; the measured number falls inside the stated range.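

Among the compounds shown here, replacing cyanomethoxy with 2-fluorophenyl on this aromatic carbon gives a 2.0-fold lower number from compound 2 to compound 3 (0.31 log units; beyond the scatter) in this assay, the first step that can be read at this position. The position therefore accepts an aromatic ring with no hydrogen-bond acceptors, and the nitrile and ether oxygen of cyanomethoxy are not required for inhibition at this level. Nothing shown gives a cause for this step. What the fluorine contributes remains open, since a plain phenyl is not among the compounds shown. A single step also leaves open how an amine or a carboxylic acid would read at this position.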